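The source may hold more compounds than are shown below. What is called first, only, known or untested is meant among the compounds shown, and "the series" means these compounds.

Measured compounds:
- Compound 1, `C[C@@H]1N[C@H](C(=O)N2CCC[C@H]2C#N)C[C@@H]1C(=O)N1CCC1`: 88%
- Compound 2, `CCN(C)C(=O)[C@H]1C[C@@H](C(=O)N2CCC[C@H]2C#N)N[C@H]1C`: 79%
- Compound 3, `CCN(C)C(=O)[C@@H]1CN[C@H](C(=O)N2CCC[C@H]2C#N)C1`: 34%

All three were tested in an assay on the whole organism (plasma, strain Sprague-Dawley) for inhibition of Dipeptidyl peptidase 4 (Rattus norvegicus), with a stated time of 10 h, at a dose of 1 mg/kg by the oral route; on this read-out higher numbers stand for more inhibition at the one dose given (going by the name of the read-out) and lower numbers for less inhibition. In this assay compound 1 gives 88%, compound 2 gives 79% and compound 3 gives 34%.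

Two changes link these compounds. From compound 2 to compound 1 the change is azetidin-1-yl in place of ethyl(methyl)amino on a carbonyl carbon, and in this assay this gave a number 9 percentage points higher from compound 2 to compound 1 (within the scatter). From compound 2 to compound 3 the change is hydrogen in place of methyl on a saturated ring carbon, and this gave a number 45 percentage points lower from compound 2 to compound 3 (beyond the scatter), so compound 3 stands lowest of the three.

Compound 4, `N#C[C@@H]1CCCN1C(=O)[C@@H]1C[C@H](C(=O)N2CCC2)CN1`, has not yet been measured in this assay. It differs from compound 3 by azetidin-1-yl in place of ethyl(methyl)amino on a carbonyl carbon. This is the same change as from compound 2 to compound 1, made on the core of compound 3 rather than the core of compound 2; the two cores differ by hydrogen in place of methyl on a saturated ring carbon. Because a number 9 percentage points higher from compound 2 to compound 1 (within the scatter) lay within the scatter, the step from compound 3 to compound 4 is expected to be small as well, roughly a number 6 percentage points higher from compound 3 to compound 4 (within the scatter). Compound 4 is therefore expected to give about 40% in this assay, with a likely range from 22% to 58%.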

Compound 4, a percentage reported as inhibition, in the whole organism at one dose (the size of the read-out at that dose, not a potency): 46%
For compound 4 the middle estimate is 6 percentage points below the measured one; low and high end bracket the measured number.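

In this assay, putting azetidin-1-yl in place of ethyl(methyl)amino on the carbonyl carbon gave a number 12 percentage points higher from compound 3 to compound 4 (beyond the scatter), and this step agrees with the one seen for the same change on the core that carries the ring methyl: the same change on two cores in this assay, a number 9 percentage points higher (within the scatter) from compound 2 to compound 1 and a number 12 percentage points higher (beyond the scatter) from compound 3 to compound 4, 3 percentage points apart, within the scatter of two such steps

Putting hydrogen in place of methyl on the saturated ring carbon gave a number 42 percentage points lower from compound 1 to compound 4 (beyond the scatter), and this step also agrees with its earlier counterpart, whichever group sits on the carbonyl carbon: the same change on two cores in this assay, a number 45 percentage points lower (beyond the scatter) from compound 2 to compound 3 and a number 42 percentage points lower (beyond the scatter) from compound 1 to compound 4, 3 percentage points apart, within the scatter of two such steps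

Within these four compounds, then, each change has about the same effect whether or not the other is present, so the outcome of one change on one core was a fair guide to its outcome on the other, but this rests on a single pair of steps per change, at one dose and one time point, and it shows neither why the numbers move nor that the agreement would hold on any other core.

The compounds shown leave open whether other groups on the carbonyl carbon, such as pyrrolidin-1-yl or diethylamino, would carry over between the two cores in the same way. They also leave open how an ethyl group in place of the methyl on the saturated ring carbon would compare.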